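The compounds below may be only part of what the source reports. "The series", "measured", "known", "first", "only" and "open" are said of these compounds alone.

Compound 1 `CC(=O)N1CC2CC(C1)N2` is the acetyl member of a small set built on a shared core. In an assay on SH-EP1 cells for agonist activity at Neuronal acetylcholine receptor; alpha4/beta2 (Homo sapiens), read by FLIPR and calcium flux (a higher number here means a larger maximal response, a lower number a smaller maximal response), compound 1 gives 95%, and compound 2 `O=C(C1CCC1)N1CC2CC(C1)N2` gives 99%, the two numbers lying within the scatter of each other. Within the data shown here, the only step measured so far, a number 4 percentage points higher from compound 1 to compound 2 (within the scatter), came with cyclobutyl in place of methyl on a carbonyl carbon. Compound 3 `O=C(CC1C=CCC1)N1CC2CC(C1)N2` carries cyclopent-2-en-1-yl in place of hydrogen on a saturated chain carbon bound to a carbonyl carbon. Among the measured compounds shown here, since the one step that bears on this change stayed within the scatter, the expected step is a number 1 percentage points higher from compound 1 to compound 3 (within the scatter), none beyond the scatter. Compound 3 is accordingly estimated at 96%, between 84% and 106%.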

Compound 3, largest response reached (Emax), in percent of the reference or control that the assay uses: 94%
Beside the measured number, compound 3's estimate is 2 percentage points above it; the measured number falls inside the stated range.
By their numbers in this assay, from the lowest: compounds 3, 1 and 2 (each within the scatter of the next).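

In this assay, the step of a number 1 percentage points lower from compound 1 to compound 3 (within the scatter) shows that a cyclopent-2-en-1-yl group on a saturated chain carbon bound to a carbonyl carbon leaves the maximal response within the scatter. The earlier compounds shown here showed this only for cyclobutyl in place of methyl on a carbonyl carbon, not for a substituent added on the chain carbon, and here a ring with a double bond enters. No measured evidence explains this result.

As far as these compounds go, whether an amine or a carboxylic acid at this place would also leave the response within the scatter stays open. So does the effect of a longer chain between the ring and the carbonyl.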